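Isobutylamino for pyrrolidin-1-yl in a series at its limit

The compounds below may be only part of what the source reports. "The series", "measured", "known", "first", "only" and "open" are said of these compounds alone.

In an ADME assay on HFF cells (Homo sapiens) for cytotoxicity, with a stated time of 8 days (on this read-out higher numbers stand for lower toxicity in this test and lower numbers for higher toxicity in this test), compound 1 `CC(C)CSc1nc(N)nc2c1ncn2/C=C1/CC1(CO)CO` gives > 300000 nM, a limit. Compound 2 `COCCOc1nc(N)nc2c1ncn2/C=C1/CC1(CO)CO` gives > 300000 nM, also a limit. Compound 3 `Nc1nc(N2CCCC2)c2ncn(/C=C3/CC3(CO)CO)c2n1` gives > 300000 nM, again a limit, so no number fixes its place.

Compound 4 `CC(C)CNc1nc(N)nc2c1ncn2/C=C1/CC1(CO)CO` has isobutylamino in place of pyrrolidin-1-yl on an aromatic carbon.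

Three measured changes at this carbon bear on it: a step that the two limits leave unreadable from compound 1 to compound 2, a step that the two limits leave unreadable from compound 1 to compound 3 and a step that the two limits leave unreadable from compound 2 to compound 3. None has a readable size. Going by the values given here, the only guide is the limit of > 300000 nM in this assay, at which 3 of the 3 values shown sit.

No change beyond the scatter is expected, and the expected step is a number no higher from compound 3 to compound 4 (the limit leaves the size open). For compound 4 the estimate is 300000 nM, with an expected range of 100000 nM to 400000 nM.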

Compound 4, half-maximal cytotoxic concentration: > 300000 nM
Compound 4 gave a limit, no number; the forecaster's own chance of this, stated with the estimate: 80%; the middle value lies on the limit itself.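

No step between compound 4 and compound 1, compound 2 or compound 3 can be read, because all the values are limits: the limit of > 300000 nM in this assay, at which 4 of the 4 values shown sit.

Whether the groups on this aromatic carbon differ at all in this test remains open, since the compounds shown give no number.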